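Bromine on the Furan Ring of a Cyanoacrylamide

A few compounds are considered here, and "the series" means these few. Any claim that something is new, unique, unknown or untested is made for them only; others in the source may bear on it.

Compounds measured so far:
- compound 1, `N#C/C(=C\c1ccc(Cl)cc1)C(=O)c1ccc[nH]1`: 43000 nM
- compound 2, `COc1ccc(CNC(=O)/C(C#N)=C/c2ccco2)cc1`: 32000 nM

In a functional assay on NCI-H460 cells (Homo sapiens) for inhibition, read by MTT assay, with a stated time of 72 h (a higher number here means a weaker inhibitor of growth, a lower number a stronger inhibitor of growth), compound 2 gives 32000 nM, the lower of the two numbers in hand. In this assay compound 1 gives 43000 nM, and the gap between compound 1 and compound 2 lies within the scatter, so neither can be called the stronger inhibitor on these data.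

Compound 3, `COc1ccc(CNC(=O)/C(C#N)=C/c2cc(Br)co2)cc1`, is not yet measured. It differs from compound 2 by bromo in place of hydrogen on an aromatic carbon. For the measured compounds named here, no pair of measured compounds shows this change, so its effect is unknown here. A single bromine added to the furan ring is a small change, and no step beyond the scatter is expected in either direction in this assay. Compound 3 is therefore estimated at 25000 nM, within a range of 8000 nM to 80000 nM, which means an expected step of a 1.3-fold lower number from compound 2 to compound 3 (0.11 log units; within the scatter).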

Compound 3, concentration for 50% growth inhibition: > 100000 nM
Compound 3 was reported as a limit (the forecaster's own chance of this, stated with the estimate: 20%); middle value at least 4.0-fold (0.60 log units) from the limit.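

In this assay compound 3 is reported only as a limit, > 100000 nM: the limit of > 100000 nM in this assay, at which 1 of the 3 values shown sits. Going from furan-2-yl to 4-bromofuran-2-yl, with the bromo group on the ring carbon two ring bonds from the ring oxygen, gives an at least 3.1-fold higher number from compound 2 to compound 3 (0.49 log units; beyond the scatter), so in this pair a single bromine at this place weakens growth inhibition rather than leaving it unchanged. For the compounds shown here, this is the first step here that can be read at all, since compound 1 and compound 2 differ in more than one place and showed only that their values lie within the scatter.

From the compounds shown here alone, whether a fluorine, a methyl group or an amine on the same ring carbon would shift the number in the same way stays open. Going by these compounds, the same is true of a bromine on the other carbons of the furan ring, and the full size of this step also remains unknown.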